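From butylamino to 4-(difluoromethoxy)phenyl on the carbonyl carbon

A few compounds are considered here, and "the series" means these few. Any claim that something is new, unique, unknown or untested is made for them only; others in the source may bear on it.

Measured in an ADME assay on Vero cells (Chlorocebus sabaeus) for cytotoxicity, read by resazurin assay, with a stated time of 3 days; on this read-out higher numbers stand for weaker inhibition and lower numbers for stronger inhibition:
- compound 1 `CCCCNC(=O)Nc1cc2nc(C3CCCCC3)[nH]c2cc1N(CC)CC`: > 100 ug/mL
- compound 2 `Cc1ccc(C(=O)Nc2cc3nc(C4CCCCC4)[nH]c3cc2N2CCCC2)cc1`: > 100 ug/mL

Compound 1 stands at > 100 ug/mL in this assay and this value is a limit. Compound 3 `CCN(CC)c1cc2[nH]c(C3CCCCC3)nc2cc1NC(=O)c1ccc(OC(F)F)cc1` has 4-(difluoromethoxy)phenyl in place of butylamino on a carbonyl carbon. Among the compounds with values here, no measured step is available. Compound 2 also carries an aromatic ring on a carbonyl carbon, and its > 100 ug/mL is likewise a limit. Resting on the limit of > 100 ug/mL in this assay, at which 2 of the 2 values shown sit, alone, the expected a number no higher from compound 1 to compound 3 (the limit leaves the size open) is none beyond the scatter. The estimated value for compound 3 is 100 ug/mL with an expected range of 40 ug/mL to 200 ug/mL in this series.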

Compound 3, half-maximal inhibitory concentration: > 100 ug/mL
Compound 3 ended at the assay's limit; the forecaster's own chance of this, stated with the estimate: 65%; the middle value lies on the limit itself.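

No step can be read from compound 1 to compound 3 in this assay, since both results are limits: the limit of > 100 ug/mL in this assay, at which 3 of the 3 values shown sit.

In this assay the compounds shown leave open whether butylamino or 4-(difluoromethoxy)phenyl on the carbonyl carbon makes any difference.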